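The source may hold more compounds than are shown below. What is called first, only, known or untested is meant among the compounds shown, and "the series" means these compounds.

Compound 1 `COc1cc2oc(-c3ccccc3)cc(=O)c2c(O)c1OCCCN1CCCC1` gives 6000 nM in a functional assay on A549 cells (Homo sapiens) for antiproliferative activity, read by MTT assay, with a stated time of 48 h; on this read-out lower numbers stand for stronger inhibition and higher numbers for weaker inhibition.
Compound 2 `O=c1cc(-c2ccccc2)oc2cc(OCc3ccccc3)c(OCCCCN3CCCC3)c(O)c12` gives 800 nM in this assay.
Compound 3 `CCN(CC)CCCOc1c(OC)cc2oc(-c3ccccc3)cc(=O)c2c1O` gives 4900 nM in this assay.

Compound 3 differs from compound 1 only by diethylamino in place of pyrrolidin-1-yl on a saturated chain carbon, three bonds along the chain from an oxygen on an aromatic ring, and this exchange produced a step of a 1.2-fold lower number from compound 1 to compound 3 (0.09 log units; within the scatter). Compound 2 shows the lowest number of the three, and the difference between its core and the core of compound 1 is not broken down here. Compound 4 `CCN(CC)CCCCOc1c(OCc2ccccc2)cc2oc(-c3ccccc3)cc(=O)c2c1O` has not yet been measured in this assay; it differs from compound 2 by diethylamino in place of pyrrolidin-1-yl on a saturated chain carbon, four bonds along the chain from an oxygen on an aromatic ring. The chain carbon lies four bonds along the chain from the aromatic oxygen rather than three. This is the same kind of change as from compound 1 to compound 3, not the same one. Since the earlier exchange gave only a 1.2-fold lower number from compound 1 to compound 3 (0.09 log units; within the scatter), a step within the scatter, compound 4 is expected to move little from compound 2, an estimated 1.1-fold lower number from compound 2 to compound 4 (0.06 log units; within the scatter). Compound 4 is therefore estimated at 700 nM, expected between 300 nM and 1600 nM.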

Compound 4, half-maximal inhibitory concentration: 1800 nM
The estimate for compound 4 lay 2.6-fold (0.41 log units) below the measured number; the measured number lies above the stated range.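

Diethylamino in place of pyrrolidin-1-yl gave a 2.3-fold higher number from compound 2 to compound 4 (0.35 log units; beyond the scatter) in this assay and so weakened inhibition on this core. The change therefore does not carry over at one size from one core to another in this series, as the two steps differ: the same change on two cores in this assay, a 1.2-fold lower number (0.09 log units; within the scatter) from compound 1 to compound 3 and a 2.3-fold higher number (0.35 log units; beyond the scatter) from compound 2 to compound 4, 2.8-fold (0.44 log units) apart, beyond the scatter of two such steps. Among the compounds shown here, with only one pair on each core, this does not show which difference between the two cores accounts for the gap, nor how the change would behave on a third core.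

The compounds shown leave open whether other amines, such as piperidine or morpholine, would follow either step. They also leave open how the same exchange would behave on a longer chain.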